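The compounds below may be only part of what the source reports. "The series", "measured", "known", "first", "only" and "open" are said of these compounds alone.

Of the compounds shown here, two have already been tested in a functional assay on Jurkat cells (Homo sapiens) for activation, with a stated time of 24 h; a higher number here means that more compound is needed for the effect, a lower number that less compound is needed. In this assay compound 1 `O=[N+]([O-])c1ccc(NCc2ccccc2O)cc1` gives "not active" (no number reported), with no number reported. Among the compounds with values here, compound 2 `Cc1ccc(-c2ccc(NCc3ccccc3O)cc2)cc1` gives 3790 nM, the only number available for the series, so compound 2 stands alone as the reference point. Compound 3 `Oc1ccccc1CNc1ccc(-c2ccccc2Cl)cc1` has not yet been measured in this assay. It differs from compound 2 in one place: 2-chlorophenyl in place of 4-methylphenyl on an aromatic carbon. Within the data shown here, no pair of measured compounds differs in a single place, so there is no measured step to lean on. Among the measured compounds shown here, with only one number known, swapping 4-methylphenyl for 2-chlorophenyl is expected to move the result only modestly, and the step is estimated as a 1.2-fold higher number from compound 2 to compound 3 (0.07 log units; within the scatter), a shift that need not exceed the usual scatter. For compound 3 the value in this assay is therefore estimated at 4500 nM, with a plausible range from 1500 nM to 15000 nM.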

Compound 3, half-maximal effective concentration: "not active" (no number reported)
Compound 3: no number reported; there is nothing to compare the estimate with.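

Within the data shown here, compound 3, like compound 1, has no number in this assay, so no step from compound 2 to compound 3 can be read. On these data alone, with a number for compound 2 alone, how far replacing 4-methylphenyl with 2-chlorophenyl shifts the result stays open. No available measurement explains this outcome.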